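A Fluorinated Imine Replaces the Amino Group

The source may report more compounds than this note shows. Statements on the series, on what has been measured and on what is new or still open speak of the compounds shown alone.

Measured compounds:
compound 1 `Nc1sc2c(c1-c1nc3ccccc3s1)CCCC2`, 253 ug/mL
compound 2 `Nc1sc2c(c1-c1nc3cc(Cl)ccc3s1)CCCC2`, 43.5 ug/mL
compound 3 `C(=C/c1ccccc1)\C=N\c1sc2c(c1-c1nc3ccccc3s1)CCC2`, 122 ug/mL

In an ADME assay on cells (Rhabdomyosarcoma cell, Homo sapiens) for cytotoxicity, read by MTT assay, with a stated time of 72 h (on this read-out higher numbers stand for lower toxicity in this test and lower numbers for higher toxicity in this test), compound 1 gives 253 ug/mL, the highest of the three numbers; compound 3 comes nearest with 122 ug/mL, and compound 2 is furthest with 43.5 ug/mL. The compound still to be measured is compound 4 `Fc1ccccc1/C=N/c1sc2c(c1-c1nc3ccccc3s1)CCCC2`. It differs from compound 1 by a group of 9 heavy atoms (7 carbon, 1 nitrogen, 1 fluorine; one six-membered aromatic ring of carbon only) in place of one nitrogen atom, on an aromatic carbon. Within the data shown here, the only single-place step among the measured compounds is a 5.8-fold lower number from compound 1 to compound 2 (0.76 log units; beyond the scatter), which concerns a chloro in place of hydrogen and leaves the amino group untouched, so it bears on the present change only loosely. Among the measured compounds shown here, compound 3 carries an imine where compound 1 carries the amino group, but it differs elsewhere as well, so no single step connects the two; its number simply stands somewhat below that of compound 1. From this, a modest lowering is expected from compound 1 to compound 4, a 2.1-fold lower number from compound 1 to compound 4 (0.32 log units; beyond the scatter). Compound 4 is therefore estimated at 120 ug/mL, within a range from 50 ug/mL to 300 ug/mL.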

Compound 4, half-maximal cytotoxic concentration: 319 ug/mL
Beside the measured number, compound 4's estimate is 2.7-fold (0.42 log units) below it; measured number outside the range, above it.
By their numbers in this assay, from the lowest: compound 2; then compound 3; then compounds 1 and 4 (each within the scatter of the next).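

In this assay, the replacement of the amino group on this aromatic carbon, next to the ring sulfur, by the fluorinated imine gives a 1.3-fold higher number from compound 1 to compound 4 (0.10 log units; within the scatter), so this change has no effect that can be told from the scatter. Among these compounds, the position therefore accepts a group of 9 heavy atoms with an added aromatic ring and 0 hydrogen-bond donors while the number remains level with that of compound 1, which no earlier single-place step could show. Nothing measured here explains this result.

The compounds shown leave open whether the fluorine matters, as no imine with an unsubstituted phenyl ring stands beside compound 4, and how an acetamide or a methylamino group would read at this carbon. They also leave open whether the chloro of compound 2 would give the same step on a compound carrying the imine.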